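Three limit values and a methylsulfanyl variant awaiting assay

This account rests on a few compounds, and the source may have more. Where it says the series, first, only, none or still open, it means among the compounds named here.

Measured compounds:
compound 1 `COc1ccccc1-c1ncnn1-c1cc(OC)c(OC)c(OC)c1`: > 10000 nM
compound 2 `COc1ccc(-n2ncnc2-c2cc(OC)c(OC)c(OC)c2)cc1`: > 10000 nM
compound 3 `COc1cc(-c2ncnn2-c2cccc([N+](=O)[O-])c2)cc(OC)c1OC`: > 10000 nM

In a functional assay on A549 cells (Homo sapiens) for antiproliferative activity, read by MTT assay, with a stated time of 72 h (a higher number here means a weaker inhibitor, a lower number a stronger inhibitor), compound 1 gives > 10000 nM, and this is a limit of the assay rather than a number. Compound 2 gives > 10000 nM in this assay, again a limit. Compound 3 gives > 10000 nM in this assay, also a limit. Going by the values given here, compound 1 therefore stands nowhere in particular among the three: all of them sit at the limit of > 10000 nM in this assay, at which 3 of the 3 values shown sit, no value separates from another, and no step between measured compounds can be drawn. Whether any of the three would differ if the assay reached further is not known.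

Compound 4 `COc1cc(-n2ncnc2-c2ccc(SC)cc2)cc(OC)c1OC` has not yet been tested in this assay. It differs from compound 1 in one place: 4-(methylsulfanyl)phenyl in place of 2-methoxyphenyl on an aromatic carbon. Among the compounds with values here, with every measured compound resting at the same limit, there is no measured step to lean on, and the expectation for the step from compound 1 to compound 4 in this assay is none beyond the scatter, which is what a number no higher from compound 1 to compound 4 (the limit leaves the size open) expresses. Compound 4 is accordingly estimated at 10000 nM in this assay, within an expected range of 3000 nM to 30000 nM, and most likely the assay will again report only a limit.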

Compound 4, half-maximal inhibitory concentration: 800 nM
Compound 4: middle estimate off by 13-fold (1.10 log units), on the high side; the measured number lies below the stated range.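

Compound 4 gives the series its first value that is a number rather than a limit. In this assay, 4-(methylsulfanyl)phenyl in place of 2-methoxyphenyl, on an aromatic carbon of a five-membered aromatic ring with 3 nitrogen, produces an at least 12-fold lower number from compound 1 to compound 4 (1.09 log units; beyond the scatter), so this place can separate compounds where the earlier values showed no separation at all. The two groups match in heavy atoms, hydrogen-bond donors, hydrogen-bond acceptors and net charge, yet the step is large, and its full size stays open because compound 1 rests at a limit: the limit of > 10000 nM in this assay, at which 3 of the 4 values shown sit.

The compounds shown hold neither 4-methoxyphenyl nor 2-(methylsulfanyl)phenyl at this place on the core of compound 1, so the effect of sulfur in place of oxygen cannot be told apart from the effect of where the substituent sits on the phenyl ring. Also open, on these data alone, is how this assay would read for a longer chain on the sulfur, such as ethylsulfanyl, or for an amine in place of methylsulfanyl.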